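The source may hold more compounds than are shown below. What is called first, only, known or untested is meant among the compounds shown, and "the series" means these compounds.

The series shares one core and varies a single group on the aromatic ring. In a functional assay on the whole organism (strain Sprague-Dawley) for inhibition, with Rattus norvegicus as the target, with a stated time of 10 min (on this read-out higher numbers stand for an effect only at larger amounts of compound and lower numbers for an effect already at smaller amounts), compound 1 `CCOC(=O)c1cnc(-c2ccccc2F)[nH]c1=O` gives > 10 mg/kg, which is a limit of the assay and not a number. Compound 2 `CCOC(=O)c1cnc(-c2ccccc2Cl)[nH]c1=O` gives 5 mg/kg. Compound 3 `CCOC(=O)c1cnc(-c2ccccc2N)[nH]c1=O` has no number to start from, as its entry reads "not determined" (no result reported).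

The change to compound 4 `CCOC(=O)c1cnc(-c2ccccc2O)[nH]c1=O` is hydroxy in place of amino on an aromatic carbon. For the measured compounds named here, the only measured step is an at least 2.0-fold lower number from compound 1 to compound 2 (0.30 log units; that floor lies within the scatter), with chloro in place of fluoro on an aromatic carbon. That step exchanges different groups, so it bears only indirectly on this change. With no value for compound 3, no size or direction of step can be expected from it.

The expectation therefore leans on compound 2 at 5 mg/kg and stays in that region. Compound 1 also counts here, with its limit of > 10 mg/kg. Compound 4 is expected at about 8 mg/kg, with an estimated range from 2 mg/kg to 30 mg/kg.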

Compound 4, dose for 50% inhibition: 5 mg/kg
For compound 4 the middle estimate is 1.6-fold (0.20 log units) above the measured one; measured number inside the range.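

Hydroxy in place of chloro brings no change at the digits printed from compound 2 to compound 4 (within the scatter), so in this assay these two groups cannot be told apart at this place on the aromatic ring. Hydroxy in place of fluoro gives an at least 2.0-fold lower number from compound 1 to compound 4 (0.30 log units; that floor lies within the scatter), a reading of the same kind as the earlier step from fluoro to chloro. That step has no exact size, and its floor stays within the usual scatter, because compound 1 is recorded only as a limit: the limit of > 10 mg/kg in this assay, at which 1 of the 4 values shown sits.

Compound 3 has no result, so the direct change from amino to hydroxy, like every other step involving compound 3, cannot be read. On these data alone, whether a methoxy group, a methyl group or a carboxylic acid at this place would give a dose different from those of compound 2 and compound 4 remains open.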